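Trimming the Amine on a Diaryl Alkyne

This account rests on a few compounds, and the source may have more. Where it says the series, first, only, none or still open, it means among the compounds named here.

Of the compounds shown here, two have been measured so far. Compound 2 `CN(C)c1ncc(C#Cc2c(F)cccc2F)c2ccccc12` gives 97.6% in a functional assay on LS174T cells (Homo sapiens) for inhibition, with a stated time of 4 days, tested at 10 uM (a lower number here means a weaker effect, a higher number a stronger effect of the compound at the concentration tested), and compound 1 `Fc1cccc(F)c1C#Cc1cncc2ccccc12` in this assay gives 87.9%; the one measured step between them, a number 9.7 percentage points higher from compound 1 to compound 2 (within the scatter), lies within the scatter, so the two numbers shown do not separate compound 2 from compound 1. Compound 3 `CNc1ncc(C#Cc2c(F)cccc2F)c2ccccc12` is not yet measured. It differs from compound 2 by hydrogen in place of methyl on a nitrogen on an aromatic ring. Within the data shown here, only one measured step bears on this nitrogen: dimethylamino in place of hydrogen on an aromatic carbon, from compound 1 to compound 2, stayed within the scatter. Among the measured compounds shown here, no measured pair shows the narrower change from dimethylamino to methylamino. Because a number 9.7 percentage points higher from compound 1 to compound 2 (within the scatter) remained within the scatter when the whole dimethylamino entered, the loss of one methyl is expected to move the inhibition no further than the scatter, an expected step of a number 3.6 percentage points lower from compound 2 to compound 3 (within the scatter). Compound 3 is therefore estimated to give 94% in this assay, in an expected range from 80% to 100%.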

Compound 3, a percentage reported as inhibition, at one concentration (the size of the read-out at that concentration, not a potency): 98.9%
Compound 3: middle estimate off by 4.9 percentage points, on the low side; the measured number falls inside the stated range.
By their numbers in this assay, from the lowest: compounds 1, 2 and 3 (each within the scatter of the next, the first and the last beyond it).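

In this assay, taking one methyl off the nitrogen leaves methylamino and dimethylamino unseparated, with a number 1.3 percentage points higher from compound 2 to compound 3 (within the scatter), so this change has no resolved effect on the read-out. The comparison with hydrogen on the aromatic carbon does add something: methylamino in that place gives a number 11 percentage points higher from compound 1 to compound 3 (beyond the scatter), a modest step and the first at this position to pass the scatter, whereas dimethylamino gave a number 9.7 percentage points higher from compound 1 to compound 2 (within the scatter). Within these three compounds, then, only methylamino is separated from hydrogen at this carbon, and nothing available explains that separation or ties it to any property of the group.

Going by these compounds, each read-out is the size of the effect at one concentration, so whether compound 2 and compound 3 would show a stronger or weaker effect at other concentrations remains open. Also open, on these data alone, is how an unsubstituted amino group, an ethylamino group or a cyclic amine such as morpholine would read at this aromatic carbon, and whether the separation from hydrogen seen with methylamino would extend to any of them.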